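Shifting a Phenol Hydroxyl Across a Shared Core

The source may report more compounds than this note shows. Statements on the series, on what has been measured and on what is new or still open speak of the compounds shown alone.

Compound 1 `Oc1ccc(-c2cc(-c3ccccc3C(F)(F)F)cc(-c3cccc(O)c3)n2)cc1` was tested in a functional assay on HeLa cells (Homo sapiens) for inhibition; on this read-out lower numbers stand for stronger inhibition and higher numbers for weaker inhibition; in this assay compound 1 gives 17400 nM. Compound 2 `Oc1ccc(-c2cc(-c3ccccc3C(F)(F)F)cc(-c3ccc(O)cc3)n2)cc1` differs from it by 4-hydroxyphenyl in place of 3-hydroxyphenyl on an aromatic carbon. In this assay compound 2 reaches only a limit, > 50000 nM, not a number. The step of an at least 2.8-fold higher number from compound 1 to compound 2 (0.45 log units; beyond the scatter) therefore rests on (the limit of > 50000 nM in this assay, at which 1 of the 3 values shown sits).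

Compound 3 `Oc1cccc(-c2cc(-c3ccc(OC(F)(F)F)cc3)cc(-c3ccccc3O)n2)c1` has a different core; how the cores of compound 1 and compound 3 differ is not broken down here. In this assay compound 3 gives 20600 nM, which lies within the scatter of the number for compound 1, so the two are not told apart.

Compound 4 `Oc1ccc(-c2cc(-c3ccc(OC(F)(F)F)cc3)cc(-c3ccccc3O)n2)cc1` has not yet been measured. It differs from compound 3 by 4-hydroxyphenyl in place of 3-hydroxyphenyl on an aromatic carbon. This is the same kind of change as that from compound 1 to compound 2, but the surroundings are not the same: in compound 1 the changed group sits meta to a 2-(trifluoromethyl)phenyl group and meta to a 4-hydroxyphenyl group, whereas in compound 3 it sits meta to a 2-hydroxyphenyl group and meta to a large group. Because the earlier step of an at least 2.8-fold higher number from compound 1 to compound 2 (0.45 log units; beyond the scatter) ended at the limit (the limit of > 50000 nM in this assay, at which 1 of the 3 values shown sits), it sets only a floor on how far the number rose. Compound 4 is accordingly expected to give about 60000 nM in this assay, plausibly between 25000 nM and 150000 nM, an expected step of a 2.9-fold higher number from compound 3 to compound 4 (0.46 log units; beyond the scatter) beside the measured one, with a real chance that only a limit is reported.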

Compound 4, half-maximal inhibitory concentration: > 50000 nM
Compound 4 gave a limit, no number (the forecaster's own chance of this, stated with the estimate: 60%); the middle value does not contradict the limit.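

In this assay compound 4 reaches only a limit, > 50000 nM, not a number. Putting 4-hydroxyphenyl in place of 3-hydroxyphenyl on this second core gives an at least 2.4-fold higher number from compound 3 to compound 4 (0.38 log units; beyond the scatter), so on both cores shown the change moves the read-out in the same direction, towards weaker inhibition, and no pair shown goes against this: the same change on two cores in this assay, an at least 2.8-fold higher number (0.45 log units; beyond the scatter) from compound 1 to compound 2 and an at least 2.4-fold higher number (0.38 log units; beyond the scatter) from compound 3 to compound 4; the limit leaves it open whether they differ What this does not show is the true size of either step, or whether the change costs more on one core than on the other, because both steps end at the same ceiling of the read-out: the limit of > 50000 nM in this assay, at which 2 of the 4 values shown sit.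

The agreement therefore rests on two pairs only, and it holds as a direction rather than as a transferable amount. The compounds shown leave open how far the number really rises on either core, and whether the same direction would hold on a core carrying other groups. They also leave open whether a methoxy group or an amine in place of the hydroxyl on this ring would give a measurable number rather than another limit.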